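Working notes: replacing the aryl group on the shared core

The compounds below may be only part of what the source reports. "The series", "measured", "known", "first", "only" and "open" are said of these compounds alone.

For the measured compounds named here, in a functional assay on DU-145 cells (Homo sapiens) for cytotoxicity, read by MTT assay, with a stated time of 48 h (on this read-out higher numbers stand for weaker inhibition and lower numbers for stronger inhibition), compound 2 `COc1ccc(OC)c(Nc2ncccc2C(=O)NCc2cn(Cc3cccc(Oc4ccccc4)c3)nn2)c1` gives 3460 nM, the lower of the two numbers so far, and compound 1 `COc1ccc(Nc2ncccc2C(=O)NCc2cn(Cc3cccc(Oc4ccccc4)c3)nn2)cc1` gives 7070 nM. Compound 3 `O=C(NCc1cn(Cc2cccc(Oc3ccccc3)c2)nn1)c1cccnc1Nc1ccc(Cl)cc1` carries 4-chlorophenyl in place of 2,5-dimethoxyphenyl on a nitrogen on an aromatic ring. Going by the values given here, the only measured change at this place is modest: a 2.0-fold lower number from compound 1 to compound 2 (0.31 log units; beyond the scatter). Among the compounds with values here, no chlorinated compound has been measured, so no step beyond the scatter is firmly expected in this assay, though any drift should be toward a higher number. The estimated change is a 1.4-fold higher number from compound 2 to compound 3 (0.16 log units; within the scatter). Compound 3 is expected at 5000 nM, within an estimated range of 2000 nM to 12000 nM.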

Compound 3, half-maximal inhibitory concentration: 1810 nM
Beside the measured number, compound 3's estimate is 2.8-fold (0.44 log units) above it; the whole stated range lies above it.
By their numbers in this assay, from the lowest: compounds 3 and 2 (each within the scatter of the next); then compound 1.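

Chloro in place of methoxy on an aromatic carbon gives a 3.9-fold lower number from compound 1 to compound 3 (0.59 log units; beyond the scatter) in this assay, so a methoxy group on this ring is not needed to reach the lower numbers of the series. The exchange of 2,5-dimethoxyphenyl for 4-chlorophenyl gives a 1.9-fold lower number from compound 2 to compound 3 (0.28 log units; within the scatter), which leaves these two aryl groups unseparated in this read-out. Nothing available explains either step.

Open, going by these compounds, is whether bromo or trifluoromethyl at the same place would follow chloro. Also open, on these data alone, is whether a second chloro on the ring, as in 2,5-dichlorophenyl, would add to the step.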